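Swapping a Naphthyl Ketone for a Furyl Ketone

The source may report more compounds than this note shows. Statements on the series, on what has been measured and on what is new or still open speak of the compounds shown alone.

Measured so far in a functional assay on PC-3 cells (Homo sapiens) for cytotoxicity, read by MTT assay, with a stated time of 48 h; on this read-out higher numbers stand for weaker inhibition and lower numbers for stronger inhibition: compound 1, `COc1cc(-c2nnc3n2NC(c2cccs2)C(C(=O)c2ccc(C)cc2)S3)cc(OC)c1OC`, gives 5090 nM. Compound 3, `COc1cc(-c2nnc3n2NC(c2cccs2)C(C(=O)c2ccc(Cl)cc2)S3)cc(OC)c1OC`, gives 32500 nM. Compound 2, `COc1cc(-c2nnc3n2NC(c2ccco2)C(C(=O)c2cccc4ccccc24)S3)cc(OC)c1OC`, gives > 100000 nM, which is a limit of the assay and not a number.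

Compound 2 therefore stands at the limit of > 100000 nM in this assay, at which 1 of the 3 values shown sits, the only one of the three measured compounds to do so; compounds 1 and 3 both have numbered values, compound 1 the lower of the two.

The unmeasured compound 4, `COc1cc(-c2nnc3n2NC(c2ccco2)C(C(=O)c2ccco2)S3)cc(OC)c1OC`, differs from compound 2 in one place: furan-2-yl in place of naphthalen-1-yl on a carbonyl carbon. Among the compounds with values here, the single measured step, a 6.4-fold higher number from compound 1 to compound 3 (0.81 log units; beyond the scatter), changes only a substituent on the ring attached to the carbonyl, whereas the step to compound 4 exchanges the whole ring, so that step bears on it only loosely. Compounds 1 and 3 show that six-membered rings at the carbonyl can give numbered values, while compound 2 with its naphthalen-1-yl sits at the limit.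

For compound 4 a numbered value is expected, weaker than compounds 1 and 3 but below the limit, with the step of an at least 2.5-fold lower number from compound 2 to compound 4 (0.39 log units; beyond the scatter) an estimate only. Compound 4 is estimated at 40000 nM, between 8000 nM and 200000 nM.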

Compound 4, half-maximal inhibitory concentration: 58300 nM
Compound 4: the middle estimate sits 1.5-fold (0.16 log units) below what was measured; low and high end bracket the measured number.
By their numbers in this assay, from the lowest: compound 1; then compounds 3 and 4 (each within the scatter of the next). At a limit, above all of these: compound 2.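

From the compounds shown here alone, exchanging the whole ring on this carbonyl carbon, rather than a substituent on it as in the earlier step, brings the read-out from a limit to a number: in this assay, furan-2-yl in place of naphthalen-1-yl gives an at least 1.7-fold lower number from compound 2 to compound 4 (0.23 log units; that floor lies within the scatter) and this figure is only a floor, so the real size of the change stays unknown. Compound 2 holds a limit of the assay and not a number: the limit of > 100000 nM in this assay, at which 1 of the 4 values shown sits. What the pair does show is that, with the rest of the molecule unchanged, a smaller ring carrying an oxygen at this place gives a numbered value in this assay, so the two carbon-only rings of naphthalen-1-yl are not required for one.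

Open, going by these compounds, is whether this carbonyl carbon would also give a numbered value with a group that is not aromatic, such as a cyclohexyl ring or a short alkyl chain, or with a furan-2-yl ring bearing an amine. Also open, on these data alone, is how far the true value of compound 2 lies from that of compound 4, and whether the same exchange would read alike on a different core.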